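This account rests on a few compounds, and the source may have more. Where it says the series, first, only, none or still open, it means among the compounds named here.

Series notes. Compound 1 `COc1cc(C)cc(-c2c(-c3ccnc(-c4ccc(C(C)=O)cc4)c3)cnn2CC#N)c1` carries an acetyl group on the outer phenyl ring, and in a functional assay on NCI-H322M cells (Homo sapiens) for inhibition, read by sulforhodamine B assay, with a stated time of 48 h (a higher number here means a weaker inhibitor of growth, a lower number a stronger inhibitor of growth), compound 1 gives only a limit, > 100000 nM, so no number is known for it. The same limit is the one recorded as the limit of > 100000 nM in this assay, at which 1 of the 2 values shown sits. Going by the values given here, compound 2 `Cc1cc(O)cc(-c2nn(CC#N)cc2-c2ccnc(-c3ccc(Oc4ccccc4)cc3)c2)c1` differs from compound 1 in more than one place, so no single step connects the two; in this assay compound 2 gives 19200 nM, which is a number rather than a limit, and that is all the two values show side by side.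

Compound 3 `COc1cc(C)cc(-c2c(-c3ccnc(-c4ccc(N(C)C)cc4)c3)cnn2CC#N)c1` is the next target. Against compound 1 the change is dimethylamino in place of acetyl on an aromatic carbon. Among the compounds with values here, no measured pair in this set shares that change, so there is no step to lean on for its size or direction. The expectation is that the step of an at least 1.4-fold lower number from compound 1 to compound 3 (0.15 log units; that floor lies within the scatter) stays modest, with compound 3 remaining weak in this assay, and its estimated value is 70000 nM, between 15000 nM and 300000 nM.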

Compound 3, concentration for total growth inhibition: > 100000 nM
Compound 3 was reported as a limit (the forecaster's own chance of this, stated with the estimate: 45%); middle value at least 1.4-fold (0.15 log units) from the limit.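

In this assay compound 3 gives > 100000 nM as a limit and not a number. No step can be read between compound 1 and compound 3, as both stand at the same limit: the limit of > 100000 nM in this assay, at which 2 of the 3 values shown sit.

The compounds shown leave open whether dimethylamino in place of acetyl on an aromatic carbon changes growth inhibition at all.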